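The compounds below may be only part of what the source reports. "The series", "measured", "known", "first", "only" and "open" are said of these compounds alone.

Compound 1 `Cc1cn(COCCO)c(=O)[nH]c1=O`, compound 2 `CN(C)c1ncnc2c1ncn2COCCO` and compound 3 `Nc1nc2c(nc(Cl)n2COCCO)c(=O)[nH]1` share a (2-hydroxyethoxy)methyl group and were tested in a functional assay (Oryctolagus cuniculus) for inhibition; a higher number here means a weaker inhibitor, a lower number a stronger inhibitor. For compound 1 the assay reports only its limit, > 400 ug/mL, and not a number. Compound 2 gives 400 ug/mL in this assay. For compound 3 the assay again reports only a limit, > 400 ug/mL, so its inhibition is not pinned to a number. On the values shown, compound 3 therefore stands at the limit of > 400 ug/mL in this assay, at which 2 of the 3 values shown sit, the edge of what this assay can see.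

Compound 4 `Nc1nc2c(nc(Br)n2COCCO)c(=O)[nH]1` has not yet been measured. It differs from compound 3 in one place: bromo in place of chloro on an aromatic carbon. Among the compounds with values here, no step between two measured compounds is available to size such an exchange, and compound 3 itself offers only a limit to build on. The step from compound 3 to compound 4 is expected to be a number no higher from compound 3 to compound 4 (the limit leaves the size open), that is, none beyond the usual scatter. Compound 4 is expected to give about 400 ug/mL, between 200 ug/mL and 1600 ug/mL, and most likely the assay will again report only a limit.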

Compound 4, concentration for 50% inhibition: 340 ug/mL
Beside the measured number, compound 4's estimate is 1.2-fold (0.07 log units) above it, and the stated range covers the measured number.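

In this assay, within the data shown here, bromo on this aromatic carbon, between two ring nitrogen atoms, gives the first real number for this pair of halogens: compound 4 gives 340 ug/mL. The exchange amounts to an at least 1.1-fold lower number from compound 3 to compound 4 (0.07 log units; that floor lies within the scatter), so bromo is tolerated here, but this floor alone does not establish a real gain over chloro. The true size of the exchange stays open because compound 3 has only a limit of the assay, not a number: the limit of > 400 ug/mL in this assay, at which 2 of the 4 values shown sit.

The compounds shown leave open how inhibition at this position would respond to a group other than these two halogens, such as an amine or a methyl group. They also leave open whether a number like that of compound 4 would survive if the (2-hydroxyethoxy)methyl group gave way to a longer chain.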